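Adding a Chloro Group to a Dimethoxyphenyl Analogue

The compounds below may be only part of what the source reports. "The series", "measured", "known", "first", "only" and "open" are said of these compounds alone.

Of the compounds shown here, three sharing one core have been tested in a functional assay on U-87MG ATCC cells for antiproliferative activity against U-87 MG (Homo sapiens), read by MTT assay, with a stated time of 48 h, tested at 10 uM; on this read-out lower numbers stand for a stronger effect and higher numbers for a weaker effect at the one concentration tested. Compound 1 `Cc1nc(-c2ccccc2)sc1C(=O)CSc1nc(-c2ccc(Cl)c(Cl)c2)c(C#N)c(=O)[nH]1` gives 92.5%. Compound 2 `Cc1nc(-c2ccccc2)sc1C(=O)CSc1nc(-c2cccc(Cl)c2)c(C#N)c(=O)[nH]1` gives 83.7%. Compound 3 `COc1ccc(-c2nc(SCC(=O)c3sc(-c4ccccc4)nc3C)[nH]c(=O)c2C#N)cc1OC` gives 69.8%.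

The two cores differ as described in 3,4-dimethoxyphenyl in place of 3-chlorophenyl on an aromatic carbon, and a number 13.9 percentage points lower from compound 2 to compound 3 (beyond the scatter). Compound 1 and compound 3 also differ by this kind of exchange, and a number 22.7 percentage points lower from compound 1 to compound 3 (beyond the scatter).

Compound 4 `COc1ccc(-c2nc(SCC(=O)c3sc(-c4ccc(Cl)cc4)nc3C)[nH]c(=O)c2C#N)cc1OC` has not yet been measured. It differs from compound 3 by chloro in place of hydrogen on an aromatic carbon. The same kind of change separates compound 2 from compound 1, where it reads chloro in place of hydrogen on an aromatic carbon and where a number 8.8 percentage points higher from compound 2 to compound 1 (within the scatter). The surroundings are not identical: in compound 1 the entering chloro sits ortho to a chloro group, whereas in compound 4 it does not.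

On the strength of that earlier step, a small change is expected from compound 3 to compound 4, about a number 4.2 percentage points higher from compound 3 to compound 4 (within the scatter), because the comparable step a number 8.8 percentage points higher from compound 2 to compound 1 (within the scatter) stayed within the scatter. Compound 4 is therefore estimated to give 74% in this assay, between 60% and 88%.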

Compound 4, a percentage reported as activity, at one concentration (the size of the read-out at that concentration, not a potency): 83.3%
The estimate for compound 4 lay 9.3 percentage points below the measured number; the range from low to high includes it.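

Putting a chloro in place of hydrogen on the phenyl group of compound 3 gave a number 13.5 percentage points higher from compound 3 to compound 4 (beyond the scatter) in this assay, so on this read-out the change leans towards a weaker effect. Set beside the earlier chloro step, the result on the two cores agrees as closely as repeated measurements allow: the same change on two cores in this assay, a number 8.8 percentage points higher (within the scatter) from compound 2 to compound 1 and a number 13.5 percentage points higher (beyond the scatter) from compound 3 to compound 4, 4.7 percentage points apart, within the scatter of two such steps

This supports carrying the change from one core to the other in these two pairs, with the number rising both times, but the first of the two steps alone stayed within the scatter. For the compounds shown here, it does not show a general rule, since only two pairs stand behind it, the chloro enters a different part of the molecule in each, and a reading at one concentration is not a potency.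

What the compounds shown leave open is how other groups would behave in place of that chloro, such as a fluoro, a methyl, an amine or a carboxylic acid. Going by these compounds, it also remains open whether a chloro entering the phenyl group of compound 1 or compound 2 would give a similar step.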